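Swapping chlorophenyl for fluoropyridyl on the ring nitrogen

A few compounds are considered here, and "the series" means these few. Any claim that something is new, unique, unknown or untested is made for them only; others in the source may bear on it.

Compound 1 `O=C(O)c1cccc(-c2ccc(/C=C3\S/C(=N\c4ccc(Cl)cc4)N(c4ccc(Cl)cc4)C3=O)o2)c1` and compound 2 `O=C(O)c1cccc(-c2ccc(/C=C3\S/C(=N\c4ccccc4)N(c4ccc(Cl)cc4)C3=O)o2)c1` share one core and differ only in a hydrogen in place of chloro on an aromatic carbon. In an ADME assay on Vero cells (Chlorocebus sabaeus) for cytotoxicity (on this read-out lower numbers stand for higher toxicity in this test and higher numbers for lower toxicity in this test), compound 1 gives only a limit, > 200000 nM. In this assay compound 2 likewise gives only a limit, > 200000 nM. The step that the two limits leave unreadable from compound 1 to compound 2 cannot be sized because both values sit at the limit of > 200000 nM in this assay, at which 2 of the 2 values shown sit. Compound 2 therefore stands at the upper limit of the measured range, with no number of its own.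

Compound 3 `O=C(O)c1cccc(-c2ccc(/C=C3\S/C(=N\c4ccccc4)N(c4ncccc4F)C3=O)o2)c1` differs from compound 2 by 3-fluoropyridin-2-yl in place of 4-chlorophenyl on an amide-type nitrogen in a ring. For the measured compounds named here, no measured step covers this exchange, and the only step available is unreadable. Compound 3 is therefore expected to remain at or near the same limit, so that the step of a number no higher from compound 2 to compound 3 (the limit leaves the size open) is expected to be small or not readable. The estimate for compound 3 in this assay is 200000 nM, within 60000 nM to 400000 nM.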

Compound 3, half-maximal cytotoxic concentration: > 200000 nM
Compound 3 gave a limit, no number (the forecaster's own chance of this, stated with the estimate: 75%); the middle value lies on the limit itself.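

No new step can be read between compound 2 and compound 3 in this assay, as both values are limits: the limit of > 200000 nM in this assay, at which 3 of the 3 values shown sit. The compounds shown leave open how the half-maximal cytotoxic concentrations of compounds 1, 2 and 3 compare, and whether either exchange alters them.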